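The source may hold more compounds than are shown below. What is called first, only, known or untested is meant among the compounds shown, and "the series" means these compounds.

Measured so far in an assay on microsomes from intestine for inhibition of acyl-CoA:cholesterol acyltransferase (Oryctolagus cuniculus); on this read-out lower numbers stand for stronger inhibition and higher numbers for weaker inhibition:
compound 1 `CCOC(=O)CC(=O)Nc1c(C(C)C)cccc1C(C)C` gives 1800 nM
compound 2 `CCCCC(C)(C)OC(=O)CC(=O)Nc1c(C(C)C)cccc1C(C)C` gives 15 nM

Compound 2 stands at the lowest of the two numbers in this assay; its nearest neighbour is compound 1, separated by a 120-fold lower number from compound 1 to compound 2 (2.08 log units; beyond the scatter). Compound 3 `CCCCCCCCOC(=O)CC(=O)Nc1c(C(C)C)cccc1C(C)C` is not yet measured. It differs from compound 2 by octyl in place of 1,1-dimethylpentyl on an oxygen next to a carbonyl group.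

Among the compounds with values here, the only measured step that bears on this position is a 120-fold lower number from compound 1 to compound 2 (2.08 log units; beyond the scatter), a large one, which shows that replacing a short ester chain by a longer one at this oxygen gives a much lower number in this assay. Within the data shown here, the change from compound 2 to compound 3 keeps a long chain and only alters its shape, so no step of that size is expected; a change within the scatter, or a little either way, is the likely outcome, expressed as a 1.3-fold higher number from compound 2 to compound 3 (0.12 log units; within the scatter).

On that basis compound 3 is expected at about 20 nM in this assay, with a range from 5 nM to 80 nM.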

Compound 3, half-maximal inhibitory concentration: 260 nM
The estimate for compound 3 lay 13-fold (1.11 log units) below the measured number, outside the stated range (above it).
By their numbers in this assay, from the lowest: compound 2; then compound 3; then compound 1.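

In this assay the gain at this oxygen does not follow chain length alone: the straight octyl chain keeps only part of it over ethyl (a 6.9-fold lower number from compound 1 to compound 3 (0.84 log units; beyond the scatter)) and falls well short of the branched 1,1-dimethylpentyl (a 17-fold higher number from compound 2 to compound 3 (1.24 log units; beyond the scatter)). The two long chains are therefore not interchangeable here, and the arrangement of the carbons matters at least as much as their number, with octyl giving the higher number despite its extra carbon. Nothing available explains this difference.

From the compounds shown here alone, it remains open whether the low number of compound 2 comes from the two methyl groups on the carbon attached to the oxygen or from the branched chain as a whole. A tert-butyl ester and a 1,1-dimethylheptyl ester would separate these two readings.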